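This account rests on a few compounds, and the source may have more. Where it says the series, first, only, none or still open, it means among the compounds named here.

Working notes on the series. Compound 1 `Cc1cc(Nc2cc(-c3ccccc3)[nH]n2)n2nc(SCCc3ccccc3)nc2n1` carries a phenethylsulfanyl group on the shared core; in a functional assay on MGC-803 cells (Homo sapiens) for inhibition, read by MTT assay, with a stated time of 72 h (on this read-out higher numbers stand for weaker inhibition and lower numbers for stronger inhibition), compound 1 gives 5620 nM. Compound 2 `Cc1cc(Nc2cc(-c3ccccc3)[nH]n2)n2nc(SCc3ccc(F)cc3)nc2n1` replaces that chain by a (4-fluorobenzyl)sulfanyl group, and in this assay compound 2 gives 3270 nM. Compound 3 `Cc1cc(Nc2cc(-c3ccccc3)[nH]n2)n2nc(SCC(=O)c3ccccc3)nc2n1` has a benzoyl on the chain carbon bound to the sulfur; in this assay compound 3 gives 2580 nM. The steps are a 1.7-fold lower number from compound 1 to compound 2 (0.24 log units; within the scatter), a 2.2-fold lower number from compound 1 to compound 3 (0.34 log units; beyond the scatter) and a 1.3-fold lower number from compound 2 to compound 3 (0.10 log units; within the scatter); only the change from compound 1 to compound 3 reaches beyond the scatter, and compound 2 stands between the other two with both of its steps inside it.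

Compound 4 `Cc1ccc(CSc2nc3nc(C)cc(Nc4cc(-c5ccccc5)[nH]n4)n3n2)cc1` differs from compound 2 by methyl in place of fluoro on an aromatic carbon, a (4-fluorobenzyl)sulfanyl becoming a (4-methylbenzyl)sulfanyl. Among the compounds with values here, no measured step changes a substituent on this aromatic ring; the steps among compounds 1, 2 and 3 alter the whole sulfur-linked group and stay small. The expectation for compound 4 in this assay is therefore no step beyond the scatter, a 1.0-fold lower number from compound 2 to compound 4 (0.01 log units; within the scatter). Compound 4 is estimated at 3200 nM, between 1500 nM and 7000 nM.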

Compound 4, half-maximal inhibitory concentration: 6960 nM
Estimate against measurement, compound 4: 2.2-fold (0.34 log units) below; low and high end bracket the measured number.
By their numbers in this assay, from the lowest: compounds 3, 2, 1 and 4 (each within the scatter of the next, the first and the last beyond it).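

In this assay, within the data shown here, a single-atom change on the aromatic ring of the sulfur-linked group is enough to move the number: methyl in place of fluoro gives a 2.1-fold higher number from compound 2 to compound 4 (0.33 log units; beyond the scatter) and so shows that this ring position, untouched by the earlier steps, is not indifferent. The (4-methylbenzyl)sulfanyl group gives a 2.7-fold higher number from compound 3 to compound 4 (0.43 log units; beyond the scatter) against the benzoyl chain, whereas the comparison with the phenethylsulfanyl group gives a 1.2-fold higher number from compound 1 to compound 4 (0.09 log units; within the scatter) and so places compound 4 with compound 1 on this read-out. Nothing on hand offers an explanation for the step from fluoro to methyl.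

From the compounds shown here alone, whether an unsubstituted benzyl, or a chloro, methoxy or trifluoromethyl group at the same ring position, would fall with fluoro or with methyl remains open. So does the effect of an amine or a carboxylic acid there.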